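The source may hold more compounds than are shown below. What is called first, only, known or untested is meant among the compounds shown, and "the series" means these compounds.

Working notes on the series, read in a functional assay on Malme-3M cells (Homo sapiens) for cytotoxicity, read by MTT assay, with a stated time of 6 days; on this read-out lower numbers stand for an effect already at smaller amounts and higher numbers for an effect only at larger amounts of compound. Compound 1 (`COc1cc(-c2cc(=O)c3ccc(O)c(O)c3o2)cc(OC)c1OC`) gives > 25 ug/mL, which is a limit of the assay and not a number. Compound 2 (`COc1cc(-c2cc(=O)c3ccc(O)cc3o2)cc(OC)c1O[Si](C)(C)C(C)(C)C`) gives > 25 ug/mL, which is likewise a limit and not a number. For the measured compounds named here, compound 2 therefore has no numeric position, and the only reading available for the series is the limit of > 25 ug/mL in this assay, at which 2 of the 2 values shown sit.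

Compound 3 (`COc1cc(-c2cc(=O)c3ccc(O)c(O)c3o2)cc(OC)c1O[Si](C)(C)C(C)(C)C`) is not yet measured. It differs from compound 2 as follows: hydroxy in place of hydrogen on an aromatic carbon. It keeps the silyl ether of compound 2 and has the same hydroxy arrangement as compound 1. No measured step sizes this change in this assay. A small shift is expected, within the scatter or slightly toward lower numbers. This expectation rests on compound 1, whose limit of > 25 ug/mL comes with the same hydroxy arrangement. The expected change is an at least 1.1-fold lower number from compound 2 to compound 3 (0.05 log units; that floor lies within the scatter). Compound 3 is estimated at 22 ug/mL, with an expected range of 8 ug/mL to 50 ug/mL.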

Compound 3, concentration for half-maximal effect: 0.2 ug/mL
Compound 3: the middle estimate sits 110-fold (2.04 log units) above what was measured; the whole stated range lies above it.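

In this assay, hydroxy in place of hydrogen on an aromatic carbon, ortho to a hydroxy group, gives an at least 120-fold lower number from compound 2 to compound 3 (2.09 log units; beyond the scatter), so this position on the part of the core that is a fused system strongly affects the read-out when the silyl ether is present. The silyl group in place of the methyl carbon, on an oxygen on an aromatic ring, gives an at least 120-fold lower number from compound 1 to compound 3 (2.09 log units; beyond the scatter), so with this hydroxy arrangement the change on the other ring counts as well, and among the compounds shown, neither change gives a numeric value without the other. Both steps are floors and not true sizes, since each starts from a limit of the assay: the limit of > 25 ug/mL in this assay, at which 2 of the 3 values shown sit.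

On these data alone, it remains open whether an amine or a methoxy group on that aromatic carbon would act as the hydroxy does, and whether a longer carbon chain on the oxygen would act as the silyl group does. The cause of the large steps also stays open, and the compounds shown do not tell whether the result depends on the silicon atom or only on the size of the group that carries it.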